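The source may report more compounds than this note shows. Statements on the series, on what has been measured and on what is new or still open speak of the compounds shown alone.

Compound 1 `COCCOc1nc(N)nc2c1ncn2/C=C1/CC1(CO)CO`: in an ADME assay on MOLT-3 cells (Homo sapiens) for cytotoxicity, with a stated time of 7 days (a higher number here means that more compound is tolerated, a lower number that less compound is tolerated), it gives a limit, > 20000 nM.
Compound 2 `CSc1nc(N)nc2c1ncn2/C=C1/CC1(CO)CO`: in this assay it gives a limit, > 20000 nM.

Compound 2 stands at the limit of this assay, not at a measured number; the same holds for the other value shown, so that (the limit of > 20000 nM in this assay, at which 2 of the 2 values shown sit). Going by the values given here, the one measured step, a step that the two limits leave unreadable from compound 1 to compound 2, has no readable size, as both of its ends are limits.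

Compound 3 `CCCCNc1nc(N)nc2c1ncn2/C=C1/CC1(CO)CO` differs from compound 2 in one place: butylamino in place of methylsulfanyl on an aromatic carbon. No measured step bears directly on this change, and the single step shown cannot be read, so there is nothing to point to a movement in either direction. The step of a number no higher from compound 2 to compound 3 (the limit leaves the size open) is therefore expected to be none beyond the scatter. Compound 3 is expected to give 20000 nM in this assay, most likely again as a limit, with a range from 8000 nM to 40000 nM.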

Compound 3, half-maximal cytotoxic concentration: > 20000 nM
Compound 3: a limit, no number (the forecaster's own chance of this, stated with the estimate: 70%); the middle value lies on the limit itself.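

In this assay compound 3 gives > 20000 nM, which is a limit and not a number. The steps to compound 3 from compound 1 and from compound 2 therefore cannot be read: the limit of > 20000 nM in this assay, at which 3 of the 3 values shown sit.

The compounds shown leave open whether exchanging these groups changes the result in this assay at all.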